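Methyl for methoxy on the aryl ring of compound 2

The source may hold more compounds than are shown below. What is called first, only, known or untested is meant among the compounds shown, and "the series" means these compounds.

Of the compounds shown here, three have been measured in a functional assay on HCT-15 cells (Homo sapiens) for cytotoxicity, read by MTT assay, with a stated time of 2 days; on this read-out lower numbers stand for stronger inhibition and higher numbers for weaker inhibition. Compound 1 `O=c1[nH]c(-c2cccc3ccccc23)nc2ccc(N3CCCCC3)cc12` gives 2240 nM. Compound 2 `COc1cccc(-c2nc3cc(C)ccc3c(=O)[nH]2)c1` gives 4850 nM, the higher of the two numbers, and the gap from compound 1 to compound 2 is beyond the scatter. Of the three values, one is a limit: the limit of > 50000 nM in this assay, at which 1 of the 3 values shown sits. Compound 3 `Cc1ccc2nc(-c3cccc(OC(F)(F)F)c3)[nH]c(=O)c2c1` is the one at that limit, reporting > 50000 nM in this assay.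

Compound 4 `Cc1cccc(-c2nc3cc(C)ccc3c(=O)[nH]2)c1` is not yet measured. It differs from compound 2 in one place: methyl in place of methoxy on an aromatic carbon. The substituent sits on an aromatic carbon of a six-membered aromatic ring of carbon only. Among the compounds with values here, no measured pair in the set isolates this change, so its size cannot be read from the data. Within the data shown here, compound 3, which carries a trifluoromethoxy group at the same place, reaches only a limit, while compound 2 with methoxy gives a number; the methyl of compound 4 is a smaller, acceptor-free group, but the set gives no measured step for it.

For compound 4 the expectation in this assay is a shift of a 1.0-fold higher number from compound 2 to compound 4 (0.01 log units; within the scatter), no larger than the scatter in either direction. Compound 4 is therefore estimated at 5000 nM, with a plausible range from 2000 nM to 15000 nM.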

Compound 4, half-maximal inhibitory concentration: 21100 nM
Estimate against measurement, compound 4: 4.2-fold (0.63 log units) below; measured number outside the range, above it.
By their numbers in this assay, from the lowest: compound 1; then compound 2; then compound 4. At a limit, above all of these: compound 3.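

In this assay, within the data shown here, the change from methoxy to methyl gives a 4.4-fold higher number from compound 2 to compound 4 (0.64 log units; beyond the scatter), the first measured step at this aromatic carbon, and it shows that the position is not indifferent to its substituent. Of the two groups with a numerical result here, methoxy gives the lower number, so the methyl group, with one heavy atom and no hydrogen-bond acceptor, does not hold the level of compound 2. Compound 3, with trifluoromethoxy at the same place, gives a limit rather than a number: the limit of > 50000 nM in this assay, at which 1 of the 4 values shown sits.

With only two numerical results at this place, the compounds shown cannot separate a role for the oxygen of methoxy from one for the size of the group, and they cannot place compound 3 on the same scale as the others. A hydroxyl, an ethoxy group or an amine on this aromatic carbon would test whether the step follows the acceptor count or the number of heavy atoms, with the rest of compound 2 unchanged.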